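Pyridin-2-yl for furan-2-yl on the shared core

The compounds below may be only part of what the source reports. "The series", "measured", "known", "first", "only" and "open" are said of these compounds alone.

Measured in a functional assay on HCT-15 cells (Homo sapiens) for cytotoxicity, read by CCK-8 assay; a lower number here means a stronger inhibitor, a higher number a weaker inhibitor:
compound 1 `Oc1cccc(-c2cc(-c3cccs3)cc(-c3ccccc3O)n2)c1` — > 50000 nM, a limit of the assay
compound 2 `Oc1cccc(-c2cc(-c3ccco3)cc(-c3ccccc3O)n2)c1` — > 50000 nM, a limit of the assay

Compound 1 gives in this assay only a limit. Compound 2 likewise gives only a limit in this assay, so its standing on the numbers shown is an upper-bound position with no measured value beneath it. The step that the two limits leave unreadable from compound 1 to compound 2 therefore has no readable size; the only evidence on the measured series is the limit of > 50000 nM in this assay, at which 2 of the 2 values shown sit, which places both shown values at the same limit.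

Compound 3 `Oc1cccc(-c2cc(-c3ccccn3)cc(-c3ccccc3O)n2)c1` differs from compound 2 as follows: pyridin-2-yl in place of furan-2-yl on an aromatic carbon. For the measured compounds named here, the one measured step, from a thiophen-2-yl to a furan-2-yl on the same carbon, bears on this change only in that it left the read-out at the limit on both sides; its size is not known. Nothing in the measured data points to a departure from the limit, so the step that the limit leaves unreadable from compound 2 to compound 3 is expected to be none readable. Compound 3 is accordingly expected to give about 70000 nM in this assay, within 20000 nM to 250000 nM, most probably reported again as a limit.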

Compound 3, half-maximal inhibitory concentration: > 50000 nM
Compound 3: only a limit was reported; the forecaster's own chance of this, stated with the estimate: 80%; the middle value does not contradict the limit.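

In this assay compound 3 gives > 50000 nM, a limit of the assay. For the compounds shown here, no step among compound 1, compound 2 and compound 3 can be read: the limit of > 50000 nM in this assay, at which 3 of the 3 values shown sit. The compounds shown leave open whether thiophen-2-yl, furan-2-yl and pyridin-2-yl differ at all on the shared core, and whether any group on that carbon gives a measurable value in this assay.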